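The source may hold more compounds than are shown below. What is called first, only, known or untested is meant among the compounds shown, and "the series" means these compounds.

In a functional assay on HL-60 cells (Homo sapiens) for antiproliferative activity, read by MTT assay, with a stated time of 6 days (on this read-out lower numbers stand for stronger inhibition and higher numbers for weaker inhibition), compound 1 `COc1ccc(/C=C/C(=O)OC[C@@H](OCc2ccccc2)[C@H]2OC(=O)C=C[C@H]2OCc2ccccc2)cc1` gives 1570 nM. Compound 2 `O=C1C=C[C@@H](OCc2ccccc2)[C@@H]([C@@H](COC(=O)/C=C/c2ccc(F)cc2)OCc2ccccc2)O1` differs from it only by fluoro in place of methoxy on an aromatic carbon, and in this assay compound 2 gives 5400 nM, so that the change brought a 3.4-fold higher number from compound 1 to compound 2 (0.54 log units; beyond the scatter). Compound 3 `COc1ccc(/C=C/C(=O)OC[C@@H](OC(C)=O)[C@H]2OC(=O)C=C[C@H]2OC(C)=O)cc1` keeps the side chain of compound 1 but sits on a different core; the difference between the two cores is not broken down here. In this assay compound 3 gives 10000 nM, the highest of the three numbers, though its gap to compound 2 falls within the scatter while its gap to compound 1 lies beyond it.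

Compound 4 `CC(=O)O[C@@H]1C=CC(=O)O[C@@H]1[C@@H](COC(=O)/C=C/c1ccc(F)cc1)OC(C)=O` has not yet been measured. It stands to compound 3 as compound 2 stands to compound 1, differing by fluoro in place of methoxy on an aromatic carbon, the same change at the same place. Among the compounds with values here, a step of similar size is expected here, a 2.8-fold higher number from compound 3 to compound 4 (0.45 log units; beyond the scatter), because the first instance of this change gave a 3.4-fold higher number from compound 1 to compound 2 (0.54 log units; beyond the scatter). Whether a number can be read at all is uncertain, since compound 3 already gives a high value. Compound 4 is therefore estimated to give about 28000 nM in this assay, most likely between 9000 nM and 70000 nM.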

Compound 4, half-maximal inhibitory concentration: 1890 nM
The estimate for compound 4 lay 15-fold (1.17 log units) above the measured number, outside the stated range (below it).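

In this assay, fluoro in place of methoxy on the aromatic carbon did not carry over from one core to the other. On the core of compound 3 the change gave a 5.3-fold lower number from compound 3 to compound 4 (0.72 log units; beyond the scatter), opposite in direction to the step seen on the core of compound 1, and the two steps clearly disagree: the same change on two cores in this assay, a 3.4-fold higher number (0.54 log units; beyond the scatter) from compound 1 to compound 2 and a 5.3-fold lower number (0.72 log units; beyond the scatter) from compound 3 to compound 4, 18-fold (1.26 log units) apart, beyond the scatter of two such steps

This shows that, for these two pairs, a step read on one core could not be transferred to the other, but it does not show which feature of the cores sets the direction, and two pairs give no rule for any further core.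

The compounds shown leave open whether the same reversal would appear with another group in that place, such as chloro, trifluoromethyl or a hydroxyl group. They also leave open how the step would run on a core bearing a longer acyl chain, such as butanoyl, in place of the acetyl groups of compound 3.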